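The source may report more compounds than this note shows. Statements on the series, on what has been measured and on what is new or still open speak of the compounds shown alone.

Measured so far:
compound 1, `CC(=O)OC1C(CCl)OC(n2c(Cl)nc3cc(Cl)c(Cl)cc32)C1OC(C)=O`: 90000 nM
compound 2, `CC(=O)OC1C(CBr)OC(n2c(Cl)nc3cc(Cl)c(Cl)cc32)C1OC(C)=O`: 60000 nM
compound 3, `O[C@@H]1[C@@H](CCl)OC(n2c(Cl)nc3cc(Cl)c(Cl)cc32)[C@@H]1O`: 90000 nM

All three were tested in a functional assay on KB cells (Homo sapiens) for inhibition; a lower number here means a stronger inhibitor, a higher number a weaker inhibitor. Compound 1 and compound 2 differ in one place only: bromo in place of chloro on a saturated chain carbon bound to a saturated ring carbon. In this assay the change gave a 1.5-fold lower number from compound 1 to compound 2 (0.18 log units; within the scatter). Compound 3 carries a different core; the difference between the core of compound 3 and the core of compound 1 is not broken down here. In this assay compound 3 is level with compound 1 at the digits reported, and its gap to compound 2 lies within the scatter.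

Compound 4, `O[C@@H]1[C@@H](CBr)OC(n2c(Cl)nc3cc(Cl)c(Cl)cc32)[C@@H]1O`, has not yet been measured. It differs from compound 3 in exactly one place: bromo in place of chloro on a saturated chain carbon bound to a saturated ring carbon. Within the data shown here, this is the same change, at the same place, as the one made between compound 1 and compound 2. Because that earlier step, a 1.5-fold lower number from compound 1 to compound 2 (0.18 log units; within the scatter), stayed within the scatter, the step to compound 4 is expected to be small as well, estimated as a 1.3-fold lower number from compound 3 to compound 4 (0.11 log units; within the scatter). In this assay compound 4 is therefore estimated at 70000 nM, most likely between 30000 nM and 160000 nM.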

Compound 4, half-maximal inhibitory concentration: 90000 nM
Compound 4: the middle estimate sits 1.3-fold (0.11 log units) below what was measured; low and high end bracket the measured number.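

In this assay, putting bromo in place of chloro on the saturated chain carbon gives no change at the digits printed from compound 3 to compound 4 (within the scatter), so this chloromethyl to bromomethyl swap makes no difference that can be told from the scatter on this core. Set beside the same swap on the core of compound 1, the result agrees with the earlier step: the same change on two cores in this assay, a 1.5-fold lower number (0.18 log units; within the scatter) from compound 1 to compound 2 and no change at the digits printed (within the scatter) from compound 3 to compound 4, 1.5-fold (0.18 log units) apart, within the scatter of two such steps

Among these compounds, this shows that the swap stayed small on both cores, but it rests on only two pairs, neither of which has a step beyond the scatter, so it does not show that a clear effect of this change would carry from one core to another.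

The compounds shown leave open whether a different group at this place, such as hydroxymethyl, aminomethyl or a longer chain, would shift the number beyond the scatter. They also leave open whether the swap would stay this small on a core that gives a much lower number in this assay.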